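Swapping an azo-linked ring for a plain phenyl

A few compounds are considered here, and "the series" means these few. Any claim that something is new, unique, unknown or untested is made for them only; others in the source may bear on it.

Three chalcone-like compounds built on a shared core have been tested in a functional assay on PC-3 cells (Homo sapiens) for antiproliferative activity, read by MTT assay, with a stated time of 48 h (a lower number here means a stronger inhibitor, a higher number a weaker inhibitor), and all three sit in the weak range. Compound 1 `C#CCOc1ccc(/C=C/C(C)=O)cc1OC` gives 40200 nM in this assay, compound 2 `COc1cc(/C=C/C(C)=O)ccc1OCc1cn(-c2ccc(/N=N/c3ccccc3)cc2)nn1` gives 42100 nM, and compound 3 `COc1cc(/C=C/C(C)=O)ccc1OCc1cn(-c2ccc(C(F)(F)F)c(C(F)(F)F)c2)nn1` gives 67200 nM. Compound 2 stands close to the other two: its value is separated from that of compound 1 and from that of compound 3 by less than the usual scatter of repeated measurements, so no ranking among the three can be drawn from these numbers.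

Compound 4 `COc1cc(/C=C/C(C)=O)ccc1OCc1cn(-c2ccc(-c3ccccc3)cc2)nn1` follows from compound 2 by a single change: a group of 6 heavy atoms (6 carbon; one six-membered aromatic ring of carbon only) in place of a group of 8 heavy atoms (6 carbon, 2 nitrogen; one six-membered aromatic ring of carbon only), on an aromatic carbon. The triazole linker and the rest of the core are unchanged.

Going by the values given here, no pair of measured compounds differs by exactly this change, so nothing measured here anchors the size of the step. Because the three measured values, including 42100 nM for compound 2, lie so close together, the expectation is that this replacement shifts the number little, neither clearly up nor clearly down, with the step from compound 2 to compound 4 expected to be a 1.1-fold higher number from compound 2 to compound 4 (0.03 log units; within the scatter). Compound 4 is estimated at 45000 nM in this assay, with a range from 18000 nM to 110000 nM.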

Compound 4, half-maximal inhibitory concentration: 56800 nM
Beside the measured number, compound 4's estimate is 1.3-fold (0.10 log units) below it; the measured number falls inside the stated range.
By their numbers in this assay, from the lowest: compounds 1, 2, 4 and 3 (each within the scatter of the next).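

In this assay, the change at this aromatic carbon, para to a large group, now has a measured size: a 1.3-fold higher number from compound 2 to compound 4 (0.13 log units; within the scatter). Going by these compounds alone, the earlier compounds offered no pair differing in one place, so this is the first step that can be read, and it shows that compound 2 and compound 4 cannot be told apart in this assay, even though the group that leaves carries a double bond outside aromatic rings and hydrogen-bond acceptors while phenyl carries no hydrogen-bond acceptors. No supporting evidence bears on this result, so it stands as a measured step without an explanation.

With one step at one position, the compounds shown leave open whether any replacement on this aromatic carbon can move the number beyond the scatter, for instance an amine, a carboxylic acid or a longer alkyl chain in place of the phenyl. They also leave open whether the same exchange would give a similar step on a different core, since this pair is the only one that can be compared.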